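This account rests on a few compounds, and the source may have more. Where it says the series, first, only, none or still open, it means among the compounds named here.

Of the compounds shown here, three of one series have been measured in a functional assay on A-375 cells (Homo sapiens) for antiproliferative activity, read by MTT assay, with a stated time of 24 h, tested at 0.41 ug/mL; on this read-out higher numbers stand for a stronger effect at the one concentration tested and lower numbers for a weaker effect. Compound 1 `Cc1ccc2nc(C(=O)Nc3c(F)cc(-c4cccc(F)c4)cc3F)c(C)c(O)c2c1` gives 1.35% in this assay. Compound 2 `CCc1ccc2nc(C(=O)Nc3c(F)cc(-c4cccc(F)c4)cc3F)c(C)c(O)c2c1`, which carries the change (methyl in place of hydrogen on a saturated chain carbon bound to an aromatic carbon), gives 3.56% in this assay, a step of a number 2.2 percentage points higher from compound 1 to compound 2 (within the scatter). Compound 3 `Cc1ccc2nc(C(=O)Nc3c(F)cc(-c4cccc(F)c4)cc3F)c(C)c(C(=O)O)c2c1` differs from compound 1 in its core by carboxy in place of hydroxy on an aromatic carbon. In this assay compound 3 gives 1.53%, a step of a number 0.2 percentage points higher from compound 1 to compound 3 (within the scatter). All three numbers are low at the single concentration tested, and none of the steps among them is beyond the usual scatter.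

Compound 4 `CCc1ccc2nc(C(=O)Nc3c(F)cc(-c4cccc(F)c4)cc3F)c(C)c(C(=O)O)c2c1` has not yet been measured. Going by the values given here, it differs from compound 3 by methyl in place of hydrogen on a saturated chain carbon bound to an aromatic carbon, the same change, at the same place, as the one from compound 1 to compound 2. For compound 4 the step expected from compound 3 is a number 2.2 percentage points higher from compound 3 to compound 4 (within the scatter), set beside the measured step of a number 2.2 percentage points higher from compound 1 to compound 2 (within the scatter), because the two changes are alike and the core difference a number 0.2 percentage points higher from compound 1 to compound 3 (within the scatter) made little difference. Compound 4 is therefore estimated at 3.7%, with the expected range running from 0% to 10%.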

Compound 4, a percentage reported as inhibition, at one concentration (the size of the read-out at that concentration, not a potency): 6.13%
Compound 4: the middle estimate sits 2.4 percentage points below what was measured; measured number inside the range.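

In this assay, methyl in place of hydrogen on a saturated chain carbon bound to an aromatic carbon gives a number 4.6 percentage points higher from compound 3 to compound 4 (within the scatter), and the two readings of this change on different cores do not differ: the same change on two cores in this assay, a number 2.2 percentage points higher (within the scatter) from compound 1 to compound 2 and a number 4.6 percentage points higher (within the scatter) from compound 3 to compound 4, 2.4 percentage points apart, within the scatter of two such steps Carboxy in place of hydroxy on an aromatic carbon, read on the other pair, gives a number 2.6 percentage points higher from compound 2 to compound 4 (within the scatter), and this change too reads alike on both cores: the same change on two cores in this assay, a number 0.2 percentage points higher (within the scatter) from compound 1 to compound 3 and a number 2.6 percentage points higher (within the scatter) from compound 2 to compound 4, 2.4 percentage points apart, within the scatter of two such steps The four compounds therefore show nothing against carrying either change from one core to the other, but with every step inside the scatter they do not show that either change has a real effect on any core, so no transfer of an effect is demonstrated.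

From the compounds shown here alone, what a longer chain such as propyl in place of the ethyl would do remains open, as does the outcome of an amine or a methyl ester in place of the carboxy. Also open, going by these compounds, is whether any such change would give a step that stands clear of the scatter.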